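From pyridin-3-yl to isopropylamino in compound 2

The source may report more compounds than this note shows. Statements on the series, on what has been measured and on what is new or still open speak of the compounds shown alone.

For the measured compounds named here, in a functional assay with Oryctolagus cuniculus as the target (a higher number here means a weaker inhibitor, a lower number a stronger inhibitor), compound 2 `COc1ccc(-c2nc(CNC(=O)c3cccnc3)sc2-c2ccc(OC)cc2)cc1` gives 25 nM and holds the lower of the two numbers so far, with compound 1 `C/N=C(/NC)Nc1nc(-c2ccc(OC)cc2)c(-c2ccc(OC)cc2)s1` higher at 970 nM in the same test. Compound 3 `COc1ccc(-c2nc(CNC(=O)NC(C)C)sc2-c2ccc(OC)cc2)cc1` carries isopropylamino in place of pyridin-3-yl on a carbonyl carbon. Going by the values given here, the one measured step (a 39-fold lower number from compound 1 to compound 2 (1.59 log units; beyond the scatter)) was large, but it lay on an aromatic carbon, a different place, so it offers only indirect guidance. A moderate rise in the number is expected (a 3.2-fold higher number from compound 2 to compound 3 (0.51 log units; beyond the scatter)) rather than a change of that size. Compound 3 is estimated at 80 nM (expected range 15 nM to 400 nM).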

Compound 3, half-maximal inhibitory concentration: 42 nM
Beside the measured number, compound 3's estimate is 1.9-fold (0.28 log units) above it; measured number inside the range.
By their numbers in this assay, from the lowest: compounds 2 and 3 (each within the scatter of the next); then compound 1.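

In this assay, the change on the carbonyl carbon gives a 1.7-fold higher number from compound 2 to compound 3 (0.23 log units; within the scatter), so within this pair the pyridin-3-yl ring can be replaced by isopropylamino, which has no ring, without a change beyond the scatter. The large difference from compound 1 also remains, at a 23-fold lower number from compound 1 to compound 3 (1.36 log units; beyond the scatter). Nothing available gives a reason for this result. Still open, on these data alone, is how far this tolerance extends on the carbonyl carbon: whether a shorter methylamino group, a larger cyclohexylamino group or a phenyl ring would give a similar number.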